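Chloro for propoxy: expected cytotoxicity shift in the series

A few compounds are considered here, and "the series" means these few. Any claim that something is new, unique, unknown or untested is made for them only; others in the source may bear on it.

Of the compounds shown here, three have been measured so far in a functional assay on MT4 cells (Homo sapiens) for cytotoxicity; on this read-out higher numbers stand for weaker inhibition and lower numbers for stronger inhibition. Compound 1 `N#Cc1c(N)cccc1Sc1ccccc1Br` gives 41000 nM. Compound 2 `CCCOc1cc(C)cc(S(=O)(=O)c2cccc(N)c2C#N)c1` gives 11000 nM, the lower of the two numbers available, and its gap to compound 1 lies beyond the scatter. Compound 3 `Cc1ccc(S(=O)(=O)c2cccc(N)c2C#N)cc1` gives > 200000 nM, and this value is a limit of the assay, not a number.

The next compound to be tested is compound 4 `Cc1cc(Cl)cc(S(=O)(=O)c2cccc(N)c2C#N)c1`. It differs from compound 2 by chloro in place of propoxy on an aromatic carbon, at a site meta to a large group and meta to a methyl group.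

Among the compounds with values here, no measured pair in the set isolates this change, so the expectation rests on the spread of values alone. With compound 2 at 11000 nM holding the lowest number, a move to a higher number in this assay is more likely than a move to a lower one, and a moderate step beyond the scatter is expected. The expected step is a 4.5-fold higher number from compound 2 to compound 4 (0.66 log units; beyond the scatter), with wide uncertainty. For compound 4 the estimated value is 50000 nM, with an expected range of 15000 nM to 180000 nM.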

Compound 4, half-maximal inhibitory concentration: > 200000 nM
Compound 4 gave a limit, no number; the forecaster's own chance of this, stated with the estimate: 25%; at least 4.0-fold (0.60 log units) between middle value and limit.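

In this assay, compound 4 gives > 200000 nM, which is a limit of the assay and not a number. Within the data shown here, this is the first change that can be read at a single place: on an aromatic carbon meta to a large group and meta to a methyl group, chloro in place of propoxy gives an at least 18-fold higher number from compound 2 to compound 4 (1.25 log units; beyond the scatter), so the read-out at this position depends strongly on the group placed there. The step marks only the smallest size the change can have, and the true gap stays hidden behind the limit: the limit of > 200000 nM in this assay, at which 2 of the 4 values shown sit.

Open, from the compounds shown here alone, is whether the lower number of compound 2 needs the whole propoxy chain, which a methoxy group, an ethoxy group or a longer chain such as butoxy at the same position would help to settle. Also open, going by these compounds, is whether the move from compound 2 to compound 4 follows from losing the propoxy chain or from bringing in chloro, since a single swap changes both at once and a hydrogen at this position would be needed to separate them.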